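This account rests on a few compounds, and the source may have more. Where it says the series, first, only, none or still open, it means among the compounds named here.

Measured in a functional assay on Bel-7402 cells (Homo sapiens) for antiproliferative activity, read by MTT assay, with a stated time of 72 h; on this read-out higher numbers stand for weaker inhibition and lower numbers for stronger inhibition:
- Compound 1 `COc1cccc(CNCc2c(C(=O)O)n(Cc3ccc(O)cc3)c3cc(C(C)C)ccc23)c1`: 7080 nM
- Compound 2 `COc1ccc(Cn2c(C(=O)O)c(CNCc3cc(OC)ccc3O)c3ccc(C)cc32)cc1`: > 50000 nM
- Compound 3 `COc1cccc(CNCc2c(C(=O)O)n(Cc3ccccc3)c3cc(C)ccc23)c1`: 12500 nM

Compound 2 gives > 50000 nM, which is a limit of this assay, not a number. It is the only limit among the three results, as the limit of > 50000 nM in this assay, at which 1 of the 3 values shown sits, records.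

Compound 4 `COc1ccc(Cn2c(C(=O)O)c(CNCc3ccc(O)c(OC)c3)c3ccc(C)cc32)cc1` has the same atoms as compound 2, joined differently: 4-hydroxy-3-methoxyphenyl in place of 2-hydroxy-5-methoxyphenyl on a saturated chain carbon bound to an amine nitrogen. Within the data shown here, no measured step covers this change, so the expectation is loose. Compound 3 gives 12500 nM, and a move toward that number is expected in this assay. The expected change is an at least 1.6-fold lower number from compound 2 to compound 4 (0.22 log units; that floor lies within the scatter), modest and toward stronger inhibition. For compound 4 the estimated value is 30000 nM, with an expected range of 10000 nM to 70000 nM.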

Compound 4, half-maximal inhibitory concentration: 13300 nM
The estimate for compound 4 lay 2.3-fold (0.35 log units) above the measured number; low and high end bracket the measured number.
By their numbers in this assay, from the lowest: compounds 1, 3 and 4 (each within the scatter of the next). At a limit, above all of these: compound 2.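

In this assay, rearranging the same atoms, 4-hydroxy-3-methoxyphenyl in place of 2-hydroxy-5-methoxyphenyl on a saturated chain carbon bound to an amine nitrogen, gives an at least 3.7-fold lower number from compound 2 to compound 4 (0.57 log units; beyond the scatter). Among these compounds, this is the first one-place comparison, and it shows that this position responds to the arrangement of the hydroxy and methoxy groups alone, with no change in atoms. Only a floor can be given for the step because compound 2 sits at a limit: the limit of > 50000 nM in this assay, at which 1 of the 4 values shown sits.

Still open, as far as these compounds go, is whether the hydroxy group, the methoxy group or both carry the difference. A 4-hydroxybenzyl or 3,4-dimethoxybenzyl group at this position, or a methyl ester in place of the carboxylic acid, would test how far it extends.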